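From a Phenol to a Boron-Bearing Ether

The source may report more compounds than this note shows. Statements on the series, on what has been measured and on what is new or still open speak of the compounds shown alone.

Three chalcones have so far been measured in a functional assay on MDA-MB-231 cells (Homo sapiens) for inhibition; on this read-out lower numbers stand for stronger inhibition and higher numbers for weaker inhibition. Compound 1 `O=C(/C=C/c1ccc(F)c(Cl)c1)c1ccc(B(O)O)cc1` gives 8500 nM. Compound 2 `O=C(/C=C/c1ccc(I)cc1)c1ccc(O)cc1` gives 8000 nM, and compound 3 `O=C(/C=C/c1ccc(B(O)O)cc1)c1ccc(Cl)c(Cl)c1` gives 8000 nM. Compound 2 stands level with compound 3 at the digits reported, and together they are the lowest of the three numbers; compound 1 differs from compound 2 by an amount that lies within the scatter, so the three cannot be ranked against one another.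

Compound 4 `O=C(/C=C/c1ccc(I)cc1)c1ccc(OCB(O)O)cc1` has not yet been measured. It differs from compound 2 by a group of 4 heavy atoms (1 carbon, 1 boron, 2 oxygen; no ring) in place of a hydrogen atom, on an oxygen on an aromatic ring. For the measured compounds named here, no pair among the measured compounds differs in exactly one place, so no measured step guides this change. What can be said is that the boron-bearing compound 1 gives 8500 nM and the boron-bearing compound 3 gives 8000 nM, both within the scatter of compound 2 at 8000 nM. The author therefore expects no change at the digits printed from compound 2 to compound 4 (within the scatter) to stay within the scatter, in no clear direction. For compound 4 the estimate is 8000 nM, with a range from 3000 nM to 25000 nM.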

Compound 4, half-maximal inhibitory concentration: 11000 nM
Compound 4: the middle estimate sits 1.4-fold (0.14 log units) below what was measured; the measured number falls inside the stated range.
By their numbers in this assay, from the lowest: compounds 2, 3, 1 and 4 (each within the scatter of the next).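

Within this assay the group of 4 heavy atoms (1 carbon, 1 boron, 2 oxygen; no ring) in place of the hydrogen atom gives a 1.4-fold higher number from compound 2 to compound 4 (0.14 log units; within the scatter) and so provides the first reading of a single change in this set. For the compounds shown here, on this oxygen on an aromatic ring, the hydrogen can therefore be replaced by this boron-bearing group without the number leaving the scatter, something the earlier compounds, with no pair differing in one place, could not show. No supporting measurement accounts for this result.

From the compounds shown here alone, whether a methyl group, a longer chain or an amine-bearing chain on the same oxygen would behave alike remains open. The compounds shown also do not separate the contribution of the boron from that of the added carbon.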